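The source may report more compounds than this note shows. Statements on the series, on what has been measured and on what is new or still open speak of the compounds shown alone.

Three compounds share one core and differ only in the group carried by the amine nitrogen on the side chain. Compound 1 `O=C(NC[C@@H]1CCCc2cc(S(=O)(=O)c3cccc(F)c3)ccc21)c1ncc[nH]1` carries an (1H-imidazol-2-yl)carbonyl there and gives 15.9 nM in an assay on isolated protein for displacement of a labelled ligand from 5-hydroxytryptamine receptor 6 (Homo sapiens); on this read-out higher numbers stand for weaker inhibition and lower numbers for stronger inhibition. Compound 2 `NC(=O)CNC[C@@H]1CCCc2cc(S(=O)(=O)c3cccc(F)c3)ccc21` carries a carbamoylmethyl and gives 0.1 nM. Compound 3 `O=S(=O)(O)CCCNC[C@@H]1CCCc2cc(S(=O)(=O)c3cccc(F)c3)ccc21` carries a 3-sulfopropyl and gives 1.26 nM, the second highest of the three numbers. The steps between them are all large: a 160-fold lower number from compound 1 to compound 2 (2.20 log units; beyond the scatter), a 13-fold lower number from compound 1 to compound 3 (1.10 log units; beyond the scatter) and a 13-fold higher number from compound 2 to compound 3 (1.10 log units; beyond the scatter).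

Compound 4 `CNCC(=O)NC[C@@H]1CCCc2cc(S(=O)(=O)c3cccc(F)c3)ccc21` is the next variation: ((methylamino)methyl)carbonyl in place of 3-sulfopropyl on an amine nitrogen. Like compound 1, compound 4 attaches a carbonyl directly to the amine nitrogen, but no measured step exchanges a 3-sulfopropyl for a carbonyl-bearing group, so the direction is read only loosely from compound 1 and compound 2. The expectation is a modest rise, a 2.4-fold higher number from compound 3 to compound 4 (0.38 log units; beyond the scatter), landing between the two. Compound 4 is therefore estimated at 3 nM, with a range from 0.5 nM to 20 nM.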

Compound 4, inhibition constant: 0.159 nM
Estimate against measurement, compound 4: 19-fold (1.28 log units) above; the whole stated range lies above it.
By their numbers in this assay, from the lowest: compounds 2 and 4 (each within the scatter of the next); then compound 3; then compound 1.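

In this assay, a carbonyl directly on the amine nitrogen does not by itself bring the weak number of compound 1: with the carbonyl kept, exchanging 1H-imidazol-2-yl for (methylamino)methyl gives a 100-fold lower number from compound 1 to compound 4 (2.00 log units; beyond the scatter) and accounts for a large change. The position also accepts this carbonyl-bearing group as well as the carbamoylmethyl, with a 1.6-fold higher number from compound 2 to compound 4 (0.20 log units; within the scatter), and the 3-sulfopropyl falls short of the new group, with a 7.9-fold lower number from compound 3 to compound 4 (0.90 log units; beyond the scatter). Nothing available explains these differences.

An acetyl group on the same nitrogen would show how much depends on the methylamino part of the new group. On these data alone, a dimethylamino or a longer aminoalkyl chain on the carbonyl, and a carboxylic acid in place of the sulfo group, also remain open.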